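Trading methoxy for cyano on a bromopyridine core

The source may report more compounds than this note shows. Statements on the series, on what has been measured and on what is new or still open speak of the compounds shown alone.

Of the compounds shown here, two have been measured in a functional assay on HEK293 cells for agonist activity at Neuronal acetylcholine receptor; alpha3/beta4 (Homo sapiens), read by FLIPR; a higher number here means that more compound is needed for the effect, a lower number that less compound is needed. Compound 1, `N#Cc1cncc(N2CC[C@H]3CN[C@H]3C2)c1`, gives 1000 nM. Compound 2, `COc1cc(N2CC[C@H]3CN[C@H]3C2)cnc1Br`, gives 8 nM in this assay, the lowest of the two numbers, and the gap from compound 1 to compound 2 is far beyond the usual scatter. Since compound 1 and compound 2 differ in more than one place, the two values alone do not show which part of the structure carries that gap.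

Compound 3, `N#Cc1cc(N2CC[C@H]3CN[C@H]3C2)cnc1Br`, is not yet measured. It differs from compound 2 in one place: cyano in place of methoxy on an aromatic carbon. The bromo group and the shared core stay as they are.

For the measured compounds named here, with no single-point step in hand, the expectation rests on the two values shown. Compound 1 carries a cyano group without bromo and gives 1000 nM, while compound 2 with methoxy and bromo gives 8 nM, so a modest rise in the number is expected for compound 3 rather than none. The step from compound 2 to compound 3 is estimated to be a 6.3-fold higher number from compound 2 to compound 3 (0.80 log units; beyond the scatter). Compound 3 is expected to give about 50 nM in this assay, within a range of 10 nM to 300 nM.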

Compound 3, half-maximal effective concentration: 4.4 nM
Beside the measured number, compound 3's estimate is 11-fold (1.06 log units) above it; the whole stated range lies above it.
By their numbers in this assay, from the lowest: compounds 3 and 2 (each within the scatter of the next); then compound 1.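

In this assay, the step at this aromatic carbon, ortho to the bromo group, is a 1.8-fold lower number from compound 2 to compound 3 (0.26 log units; within the scatter), so this read-out does not separate methoxy from cyano at this position when the bromo group is present. For the compounds shown here, the cyano group is therefore compatible with a low number, which could not be seen while the only cyano compound measured was also the one with the high number. With the cyano group held constant, bromo in place of hydrogen on an aromatic carbon gives a 230-fold lower number from compound 1 to compound 3 (2.36 log units; beyond the scatter), and among the single-place changes now available, this is the only one beyond the scatter.

The compounds shown leave open how an amine, a carboxylic acid or a longer chain such as ethoxy would read at this same carbon, and whether the bromo step would be as large with methoxy in place of cyano. No measurement at hand explains why adding the bromo group gives such a large step while exchanging methoxy for cyano does not.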